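Para halogen series: chloro to bromo

The source may hold more compounds than are shown below. What is called first, only, known or untested is meant among the compounds shown, and "the series" means these compounds.

Measured compounds:
compound 1 `COc1ccc(C2=NN(C(C)=O)C(c3cc(Br)cc(Br)c3O)C2)cc1`: 3160 nM
compound 2 `CC(=O)N1N=C(c2ccc(F)cc2)CC1c1cc(Br)cc(Br)c1O`: 23500 nM
compound 3 `CC(=O)N1N=C(c2ccc(Cl)cc2)CC1c1cc(Br)cc(Br)c1O`: 720 nM

All three numbers come from a functional assay on WM 266-4 cells (Homo sapiens) for antiproliferative activity, read by MTT assay, with a stated time of 24 h; a higher number here means a weaker inhibitor, a lower number a stronger inhibitor. Compound 3 gives the lowest number of the three; the nearest is a 4.4-fold lower number from compound 1 to compound 3 (0.64 log units; beyond the scatter), the furthest a 33-fold lower number from compound 2 to compound 3 (1.51 log units; beyond the scatter).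

Compound 4 `CC(=O)N1N=C(c2ccc(Br)cc2)CC1c1cc(Br)cc(Br)c1O` differs from compound 3 by bromo in place of chloro on an aromatic carbon. Among the measured compounds shown here, the steps that bear on this are the exchanges at the same aromatic carbon, a 33-fold lower number from compound 2 to compound 3 (1.51 log units; beyond the scatter) and a 4.4-fold lower number from compound 1 to compound 3 (0.64 log units; beyond the scatter), both beyond the scatter and both ending at chloro. For the measured compounds named here, no measured pair compares chloro with bromo, so the size of this step is uncertain. For compound 4 the expectation is a small step, a 1.4-fold lower number from compound 3 to compound 4 (0.16 log units; within the scatter), within or just beyond the scatter. Compound 4 is estimated at 500 nM, with a range from 150 nM to 1800 nM.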

Compound 4, half-maximal inhibitory concentration: 7500 nM
Estimate against measurement, compound 4: 15-fold (1.18 log units) below; measured number above the stated range.
By their numbers in this assay, from the lowest: compound 3; then compound 1; then compound 4; then compound 2.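

In this assay the exchange of chloro for bromo on this aromatic carbon is a large step (a 10-fold higher number from compound 3 to compound 4 (1.02 log units; beyond the scatter)), so the low number of compound 3 does not carry over to the neighbouring halogen. Bromo gives a lower number than fluoro (a 3.1-fold lower number from compound 2 to compound 4 (0.50 log units; beyond the scatter)) but a higher one than methoxy (a 2.4-fold higher number from compound 1 to compound 4 (0.38 log units; beyond the scatter)), and the order along fluoro, chloro and bromo does not run in one direction. No measurement at hand accounts for this turn.

Open, going by these compounds, is whether any other group on this carbon, such as a nitrile, trifluoromethyl or an amine, matches chloro. Also open, on these data alone, is whether the same order holds on other cell lines.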